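This account rests on a few compounds, and the source may have more. Where it says the series, first, only, none or still open, it means among the compounds named here.

Four compounds share one core, and three of them have been measured in a functional assay on HeLa cells (Homo sapiens) for inhibition, read by MTT assay, with a stated time of 48 h; on this read-out lower numbers stand for stronger inhibition and higher numbers for weaker inhibition. Compound 1 `CCN1C(=O)CN(C2CCCC2)c2nc(Nc3ccc(N4CCN(C)CC4)cc3)ncc21` gives 28300 nM. Compound 2 `CCN1C(=O)CN(C2CCCC2)c2nc(Nc3ccc(N4CCCCC4)cc3)ncc21` reaches only the limit of the assay, > 30000 nM. Compound 3 `CCN1C(=O)CN(C2CCCC2)c2nc(Nc3ccc(N4CCN(C)CC4)cn3)ncc21` gives 29100 nM, and this value sits within the scatter of the value of compound 1, so no order between the two can be read. The difference between the cores of compound 1 and compound 3 is not broken down here.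

From compound 1 to compound 2 the change is piperidin-1-yl in place of 4-methylpiperazin-1-yl on an aromatic carbon and the step measured is an at least 1.0-fold higher number from compound 1 to compound 2 (0.02 log units; that floor lies within the scatter); its size can only be given as a floor because of the limit of > 30000 nM in this assay, at which 1 of the 3 values shown sits.

Compound 4 `CCN1C(=O)CN(C2CCCC2)c2nc(Nc3ccc(N4CCCCC4)cn3)ncc21` has not yet been measured. It arises from compound 3 by the same kind of change, (piperidin-1-yl in place of 4-methylpiperazin-1-yl on an aromatic carbon), but the aromatic ring that carries the group holds one nitrogen rather than carbon only, and the group stands two atoms from that ring nitrogen.

The step from compound 3 to compound 4 is expected to be a 1.2-fold higher number from compound 3 to compound 4 (0.09 log units; within the scatter), resting on the measured step from compound 1 to compound 2, an at least 1.0-fold higher number from compound 1 to compound 2 (0.02 log units; that floor lies within the scatter). For compound 4 the expected value in this assay is 36000 nM, between 20000 nM and 65000 nM.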

Compound 4, half-maximal inhibitory concentration: 17600 nM
Compound 4: middle estimate off by 2.0-fold (0.31 log units), on the high side; measured number below the stated range.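

In this assay, putting piperidin-1-yl in place of 4-methylpiperazin-1-yl on the core of compound 3 gives a 1.7-fold lower number from compound 3 to compound 4 (0.22 log units; within the scatter), so on this core the change cannot be told apart from the ordinary scatter of repeated measurements. Set beside the same change on the core of compound 1, the two steps cannot be called alike or different: the same change on two cores in this assay, an at least 1.0-fold higher number (0.02 log units; that floor lies within the scatter) from compound 1 to compound 2 and a 1.7-fold lower number (0.22 log units; within the scatter) from compound 3 to compound 4; the limit leaves it open whether they differ Compound 2 gives > 30000 nM, which is a limit of the assay and not a number, so these data show neither that the change carries over from one core to the other nor that it fails to do so.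

Still open, on these data alone, is how a morpholine ring, an unsubstituted piperazine or an open-chain amine in the same place would read out on either core. Also open, as far as these compounds go, is how this change behaves on a related core whose compounds give numbers well under the limit, where both members of a pair could be read in full.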